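The compounds below may be only part of what the source reports. "The series", "measured", "known", "first", "only" and "open" are said of these compounds alone.

Compound 1 `COc1cc(C(=O)c2sc3ccccc3c2-c2ccc(SC)cc2)cc(OC)c1OC`: 1800 nM
Compound 2 `COc1ccc(OC)c(-c2c(C(=O)c3cc(OC)c(OC)c(OC)c3)sc3ccccc23)c1`: > 10000 nM (a limit)
Compound 3 `COc1ccc(-c2c(C(=O)c3cc(OC)c(OC)c(OC)c3)sc3ccccc23)cc1C`: > 10000 nM (a limit)

In a functional assay on K562 cells (Homo sapiens) for antiproliferative activity, read by MTT assay, with a stated time of 72 h (a higher number here means a weaker inhibitor, a lower number a stronger inhibitor), compound 3 gives > 10000 nM, which is a limit and not a number. It sits at the limit of > 10000 nM in this assay, at which 2 of the 3 values shown sit. Compound 4 `COc1cc(C(=O)c2sc3ccccc3c2Nc2ccccc2)cc(OC)c1OC` differs as follows: anilino in place of 4-methoxy-3-methylphenyl on an aromatic carbon. In words, anilino replaces 4-methoxy-3-methylphenyl on an aromatic carbon.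

Two measured steps change the group at this place: an at least 5.5-fold higher number from compound 1 to compound 2 (0.74 log units; beyond the scatter) and an at least 5.5-fold higher number from compound 1 to compound 3 (0.74 log units; beyond the scatter). The third, a step that the two limits leave unreadable from compound 2 to compound 3, gives no size. None of them brings in anilino, so the expectation is loose. Only compound 1 gives a number, 1800 nM, and the expectation is for a modest move towards it at most. The estimated step is an at least 1.6-fold lower number from compound 3 to compound 4 (0.22 log units; that floor lies within the scatter). Compound 4 is expected at 6000 nM, with an estimated range of 1500 nM to 20000 nM.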

Compound 4, half-maximal inhibitory concentration: 2300 nM
For compound 4 the middle estimate is 2.6-fold (0.42 log units) above the measured one; the measured number falls inside the stated range.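

For the compounds shown here, compound 1 was the only earlier compound with a number rather than a limit, and compound 4 adds a second group at this position that gives a number in this assay. Anilino, joined through nitrogen, gives an at least 4.3-fold lower number from compound 3 to compound 4 (0.63 log units; beyond the scatter) and an at least 4.3-fold lower number from compound 2 to compound 4 (0.63 log units; beyond the scatter), and both sizes are floors: the limit of > 10000 nM in this assay, at which 2 of the 4 values shown sit.

Against 4-(methylsulfanyl)phenyl, anilino is not separated, with a 1.3-fold higher number from compound 1 to compound 4 (0.11 log units; within the scatter).

Still open, going by these compounds, is how a benzylamino or morpholino group would read at this position, and whether a methoxy group on the anilino ring would shift the value.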